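Replacing methyl with trifluoromethyl on compound 3

A few compounds are considered here, and "the series" means these few. Any claim that something is new, unique, unknown or untested is made for them only; others in the source may bear on it.

In an ADME assay on HepG2 2.2.15 cells (Homo sapiens) for cytotoxicity, read by CCK-8 assay, with a stated time of 8 days (on this read-out lower numbers stand for higher toxicity in this test and higher numbers for lower toxicity in this test), compound 1 `CCOc1ccc(-c2cc(NC(=O)c3ccccc3O)c[nH]c2=O)cc1` gives 41000 nM and compound 2 `CCOc1ccc(-c2cc(NC(=O)c3ccc(Cl)cc3O)c[nH]c2=O)cc1` gives 28600 nM with a 1.4-fold lower number from compound 1 to compound 2 (0.16 log units; within the scatter) as the step for chloro in place of hydrogen. Compound 3 `CCOc1ccc(-c2cc(NC(=O)c3ccc(C)cc3O)c[nH]c2=O)cc1` gives > 100000 nM as a limit of the assay and not a number. That places it at the limit of > 100000 nM in this assay, at which 1 of the 3 values shown sits, and gives no exact value from which to count.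

Methyl in place of hydrogen gave an at least 2.4-fold higher number from compound 1 to compound 3 (0.38 log units; beyond the scatter) and methyl in place of chloro gave an at least 3.4-fold higher number from compound 2 to compound 3 (0.54 log units; beyond the scatter) so methyl alone has moved the number upward. Compound 4 `CCOc1ccc(-c2cc(NC(=O)c3ccc(C(F)(F)F)cc3O)c[nH]c2=O)cc1` carries the change trifluoromethyl in place of methyl on an aromatic carbon with trifluoromethyl in place of methyl on an aromatic carbon. With methyl gone, a modest step to a lower number is expected, and compound 2 at 28600 nM is the closest guide. The expected change is an at least 3.1-fold lower number from compound 3 to compound 4 (0.49 log units; beyond the scatter) in this assay at this estimate. Compound 4 is estimated at 32000 nM with an expected range of 12000 nM to 90000 nM for this read-out.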

Compound 4, half-maximal cytotoxic concentration: 22200 nM
The estimate for compound 4 lay 1.4-fold (0.16 log units) above the measured number, and the stated range covers the measured number.
By their numbers in this assay, from the lowest: compounds 4, 2 and 1 (each within the scatter of the next). At a limit, above all of these: compound 3.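

In this assay, the step of an at least 4.5-fold lower number from compound 3 to compound 4 (0.65 log units; beyond the scatter) shows that the rise seen with methyl at this position does not carry over to trifluoromethyl, although both are single-carbon groups. Against chloro the change is a 1.3-fold lower number from compound 2 to compound 4 (0.11 log units; within the scatter), and against hydrogen it is a 1.8-fold lower number from compound 1 to compound 4 (0.27 log units; within the scatter), so hydrogen, chloro and trifluoromethyl here stay within the scatter of one another and only methyl stands apart. Compound 3 is held at a limit of the assay and not a number: the limit of > 100000 nM in this assay, at which 1 of the 4 values shown sits.

The compounds shown leave open whether an ethyl, a methoxy or an amine at this position would stand with methyl or with the other three groups. Going by these compounds, how far compound 3 actually lies past its limit also stays open, so the full size of its step cannot be read.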